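Benzofuran replaces ethylfuran on the alkyne of compound 3

A few compounds are considered here, and "the series" means these few. Any claim that something is new, unique, unknown or untested is made for them only; others in the source may bear on it.

Of the compounds shown here, three sharing one core have been measured in an assay on CHO cells for displacement of a labelled ligand from adenosine receptor A1 (Homo sapiens), read by scintillation counting, with a stated time of 60 min, tested at 10 uM; a higher number here means more inhibition at the concentration tested (going by the name of the read-out), a lower number less inhibition. Compound 1 `CNC(=O)[C@@]12C[C@@H]1[C@@H](n1cnc3c(NC)nc(C#Cc4cccc(F)c4)nc31)[C@H](O)[C@@H]2O` gives 14%. Compound 2 `CNC(=O)[C@@]12C[C@@H]1[C@@H](n1cnc3c(NC)nc(C#Cc4ccc(F)cc4)nc31)[C@H](O)[C@@H]2O` gives 27%. Compound 3 `CCc1ccc(C#Cc2nc(NC)c3ncn([C@H]4[C@H](O)[C@H](O)[C@]5(C(=O)NC)C[C@H]45)c3n2)o1` gives 18%, which places it second highest of the three numbers; its nearest neighbour is compound 1, its furthest compound 2, and both of those gaps lie within the scatter.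

All three differ only in the group on the triple-bonded carbon. The step of a number 13 percentage points higher from compound 1 to compound 2 (beyond the scatter) is the only one beyond the scatter, while a number 4 percentage points higher from compound 1 to compound 3 (within the scatter) and a number 9 percentage points lower from compound 2 to compound 3 (within the scatter) stay within it.

Compound 4 `CNC(=O)[C@@]12C[C@@H]1[C@@H](n1cnc3c(NC)nc(C#Cc4cc5ccccc5o4)nc31)[C@H](O)[C@@H]2O` differs from compound 3 by 1-benzofuran-2-yl in place of 5-ethylfuran-2-yl on a triple-bonded carbon. Among the compounds with values here, no measured step shows the effect of the entering 1-benzofuran-2-yl, so the expectation rests on the observation that exchanging groups at this position has moved this assay by at most a modest amount. Compound 4 is therefore expected to give about 20%, within a range from 5% to 40%. The step this implies, a number 2 percentage points higher from compound 3 to compound 4 (within the scatter), is expected to remain within the usual scatter, with no direction favoured.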

Compound 4, a percentage reported as inhibition, at one concentration (the size of the read-out at that concentration, not a potency): 13%
The estimate for compound 4 lay 7 percentage points above the measured number; the measured number falls inside the stated range.
By their numbers in this assay, from the lowest: compounds 4, 1, 3 and 2 (each within the scatter of the next, the first and the last beyond it).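

Read in the assay (this assay), the larger 1-benzofuran-2-yl, which adds a six-membered aromatic ring of carbon only to the five-membered ring of 5-ethylfuran-2-yl, leaves the reading within the scatter of the furan: (a number 5 percentage points lower from compound 3 to compound 4 (within the scatter)), and the same holds against 3-fluorophenyl (a number 1 percentage points lower from compound 1 to compound 4 (within the scatter)). Within the data shown here, the only new step beyond the scatter is the one from 4-fluorophenyl (a number 14 percentage points lower from compound 2 to compound 4 (beyond the scatter)), so both steps of this size at the triple-bonded carbon now start from or lead to compound 2, although compound 3 goes against any separate standing for compound 2, its step to that compound lying within the scatter. No evidence is at hand to account for the size of these steps.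

From the compounds shown here alone, all four groups on the alkyne are aromatic rings without a charge, so it stays open how this reading would respond to an amine or a carboxylic acid on the ring, or to a longer chain in place of the ethyl of compound 3. Each figure is also a reading at one concentration, which leaves the potency of these compounds open.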